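The source may hold more compounds than are shown below. What is called first, only, known or untested is meant among the compounds shown, and "the series" means these compounds.

Measured so far in a functional assay on FM3A cells (Mus musculus) for antiproliferative activity, with a stated time of 48 h; a lower number here means a stronger inhibitor, a higher number a weaker inhibitor:
compound 1, `C=C(Br)C(=O)Nc1ccc(C(=O)/C=C/c2ccc(OC)cc2OC)cc1`, gives 1200 nM;
compound 2, `C=C(Br)C(=O)Nc1ccc(C(=O)/C=C/c2ccc(OC)c(OC)c2OC)cc1`, gives 530 nM;
compound 3, `COc1ccccc1/C=C/C(=O)c1ccc(N)cc1`, gives 25000 nM.

Within the first pair, a 2.3-fold lower number from compound 1 to compound 2 (0.35 log units; beyond the scatter); the change is methoxy in place of hydrogen on an aromatic carbon.

Compound 4, `COc1cccc(/C=C/C(=O)c2ccc(N)cc2)c1OC`, is not yet measured. It differs from compound 3 by methoxy in place of hydrogen on an aromatic carbon. The difference between the core of compound 3 and that of compound 1 is not broken down here. The change from compound 3 to compound 4 is the same kind of change as that from compound 1 to compound 2, not the same: in compound 1 the entering group sits ortho to two methoxy groups, in compound 3 ortho to one methoxy group. Compound 3 stands highest of the three numbers.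

Resting on the modest step seen in a 2.3-fold lower number from compound 1 to compound 2 (0.35 log units; beyond the scatter), a step of similar size is expected from compound 3 to compound 4, namely a 2.3-fold lower number from compound 3 to compound 4 (0.36 log units; beyond the scatter). Compound 4 is therefore estimated at 11000 nM, expected between 4000 nM and 30000 nM.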

Compound 4, half-maximal inhibitory concentration: 29000 nM
Estimate against measurement, compound 4: 2.6-fold (0.42 log units) below; the measured number falls inside the stated range.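

In this assay the added methoxy on the core of compound 3 brings a 1.2-fold higher number from compound 3 to compound 4 (0.06 log units; within the scatter) and so no change that can be read on this core. Set against the earlier step, the gap between the two does not separate the cores: the same change on two cores in this assay, a 2.3-fold lower number (0.35 log units; beyond the scatter) from compound 1 to compound 2 and a 1.2-fold higher number (0.06 log units; within the scatter) from compound 3 to compound 4, 2.6-fold (0.42 log units) apart, within the scatter of two such steps. With one pair per core, this shows neither that the gain on the core of compound 1 carries over to the core of compound 3 nor that it fails to.

Open, on these data alone, is whether another group at the same place on the core of compound 3, such as hydroxyl, chlorine or an ethoxy chain, gives a step beyond the scatter. Also open, as far as these compounds go, is whether methoxy at another place on that ring does so.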